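The compounds below may be only part of what the source reports. "The series", "measured", "known", "first", "only" and "open" are said of these compounds alone.

Measured in an ADME assay on THP-1 cells (Homo sapiens) for cytotoxicity; on this read-out lower numbers stand for stronger inhibition and higher numbers for weaker inhibition:
compound 1 `COc1ccccc1-c1nnc(-c2ccc(C(=O)N/N=C/c3cccc(O)c3)cc2)o1` gives 398000 nM
compound 2 `COc1ccccc1-c1nnc(-c2ccc(C(=O)N/N=C/c3ccc(Cl)cc3Cl)cc2)o1` gives 78800 nM

Compound 1 stands at the highest of the two numbers; its nearest neighbour is compound 2, reached by a 5.1-fold lower number from compound 1 to compound 2 (0.70 log units; beyond the scatter). The step followed here leads from compound 1 to the unmeasured compound 3 `COc1ccc(O)c(/C=N/NC(=O)c2ccc(-c3nnc(-c4ccccc4OC)o3)cc2)c1`: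
2-hydroxy-5-methoxyphenyl in place of 3-hydroxyphenyl on a carbon with a double bond to nitrogen
Among the measured compounds shown here, the only measured step, the one from compound 1 to compound 2, exchanges the same group on the same carbon with a double bond to nitrogen, but for a ring carrying chlorine rather than oxygen; it shows only that variation at this place shifts the number, and no measured pair shows what the 2-hydroxy-5-methoxyphenyl itself does. In this assay a step smaller than that one is therefore expected for compound 3, with no direction settled beyond the scatter. The estimate for compound 3 is 300000 nM, within 120000 nM to 750000 nM, which means a 1.3-fold lower number from compound 1 to compound 3 (0.12 log units; within the scatter).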

Compound 3, half-maximal inhibitory concentration: 303000 nM
The estimate for compound 3 lay 1.0-fold (0.00 log units) below the measured number, and the stated range covers the measured number.
By their numbers in this assay, from the lowest: compound 2; then compounds 3 and 1 (each within the scatter of the next).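

In this assay, replacing the 3-hydroxyphenyl with the 2-hydroxy-5-methoxyphenyl on the carbon with a double bond to nitrogen gives a 1.3-fold lower number from compound 1 to compound 3 (0.12 log units; within the scatter), so the larger group does not separate from the smaller one at this place. Among the compounds shown here, the comparison with the chlorine-bearing ring gives a 3.8-fold higher number from compound 2 to compound 3 (0.58 log units; beyond the scatter), which leaves the two oxygen-bearing rings of compounds 1 and 3 together and compound 2 apart from both, with no compound of the three going against this. Nothing measured bears on the cause of these steps.

The compounds shown do not separate the contribution of the hydroxy group from that of the methoxy group within the 2-hydroxy-5-methoxyphenyl. From the compounds shown here alone, how a ring carrying an amine or a carboxylic acid would read at this place in this assay also remains open.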